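This account rests on a few compounds, and the source may have more. Where it says the series, first, only, none or still open, it means among the compounds named here.

Measured in a physicochemical assay for lipophilicity, read by HPLC; a higher number here means a more lipophilic compound, a lower number a more polar compound:
- Compound 1 `Cc1ccsc1C(=CCCN(C)C(CCO)C(=O)NCc1ccc(F)cc1)c1sccc1C`: 5.87
- Compound 2 `Cc1ccsc1C(=CCCN(C)C(CCO)C(=O)NCc1ccccc1Cl)c1sccc1C`: 6.23
- Compound 3 `Cc1ccsc1C(=CCCN(C)C(CCO)C(=O)NCc1ccc(Cl)cc1)c1sccc1C`: 6.38

Compound 3 stands at the top of this small set only in relation to compound 1. Against compound 2 the measurement does not separate it: a number 0.15 log units higher from compound 2 to compound 3 (within the scatter). The clear differences are those that replace the fluoro compound with a chloro one: a number 0.51 log units higher from compound 1 to compound 3 (beyond the scatter), and a number 0.36 log units higher from compound 1 to compound 2 (beyond the scatter).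

Compound 4 `Cc1ccsc1C(=CCCN(C)C(CCO)C(=O)NC(C)c1ccccc1)c1sccc1C` differs from compound 3 at one place: 1-phenylethyl in place of 4-chlorobenzyl on an amide-type nitrogen. In short, 1-phenylethyl stands in place of 4-chlorobenzyl on an amide-type nitrogen, so the chlorine leaves. The closest guide is therefore the modest chloro-for-fluoro step, a number 0.51 log units higher from compound 1 to compound 3 (beyond the scatter), which suggests that a compound without chlorine may read lower. Within the data shown here, that guide is imperfect, since compound 4 carries no fluoro group either, and no measured compound contains 1-phenylethyl. The expected fall is therefore set smaller than that step, and the range is kept wide.

The expected step is a number 0.28 log units lower from compound 3 to compound 4 (within the scatter), a small fall that may not clear the scatter. The estimated value for compound 4 is 6.1, with an expected range from 5.75 to 6.45.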

Compound 4, partition coefficient: 6.1
Beside the measured number, compound 4's estimate shows no gap at the digits printed; measured number inside the range.
By their numbers in this assay, from the lowest: compounds 1, 4, 2 and 3 (each within the scatter of the next, the first and the last beyond it).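

In this assay, putting 1-phenylethyl in place of 4-chlorobenzyl on the amide-type nitrogen gives a step that stays within the scatter (a number 0.28 log units lower from compound 3 to compound 4 (within the scatter)), and the same holds for the steps from the other two compounds (a number 0.13 log units lower from compound 2 to compound 4 (within the scatter); a number 0.23 log units higher from compound 1 to compound 4 (within the scatter)), so compound 4 cannot be told apart from any of the three earlier compounds. The earlier compounds shown here only exchanged one halogen for another or moved the chlorine, whereas this group has no halogen at all, with the same 8 heavy atoms as 4-chlorobenzyl, so a halogen on this group is not needed for a reading that overlaps with both chloro compounds. Nothing measured here offers a reason for this reading.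

Still open, from the compounds shown here alone, is how a plain benzyl group on the same nitrogen would read, a comparison that would separate the loss of the chlorine from the extra carbon of 1-phenylethyl. Also open, going by these compounds, is whether a carboxylic acid or an amine on the phenyl ring of this group would give a step beyond the scatter.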